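This account rests on a few compounds, and the source may have more. Where it says the series, first, only, none or still open, it means among the compounds named here.

The three measured compounds and their permeabilities:

compound 1, `Cc1ccc(Oc2ccc3nc(COc4cccc(C(=O)O)c4)n(C)c3n2)cc1`, gives 12.6 10^-6 cm/s
compound 2, `Cc1ccc(Oc2cc3c(cn2)nc(COc2cccc(C(=O)O)c2)n3C)cc1`, gives 6.8 10^-6 cm/s
compound 3, `Cn1c(COc2cccc(C(=O)O)c2)nc2ccc(Oc3ccc(Cl)cn3)cc21`, gives 16.2 10^-6 cm/s

In an ADME assay for permeability, using PAMPA, with a stated time of 4 h (on this read-out higher numbers stand for higher permeability and lower numbers for lower permeability), compound 3 stands highest of the three numbers. Its nearest neighbour is compound 1, whose number is lower by an amount that sits within the usual scatter of repeated measurements, so the two cannot be placed in any order. The furthest is compound 2, whose number lies lower by a gap that goes beyond the scatter.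

The account now turns to compound 4, `Cc1cnc(Oc2ccc3nc(COc4cccc(C(=O)O)c4)n(C)c3c2)c(F)c1`, which has not been measured in this assay. It differs from compound 3 in one place: 3-fluoro-5-methylpyridin-2-yl in place of 5-chloropyridin-2-yl on an oxygen on an aromatic ring. Cut one bond further out, the same difference reads (5-chloropyridin-2-yl)oxy to (3-fluoro-5-methylpyridin-2-yl)oxy.

Going by the values given here, no pair of measured compounds differs in this single place, so the three measured values give no step that could be carried over directly. Both groups keep one six-membered aromatic ring with one hetero atom, no hydrogen-bond donor and one hydrogen-bond acceptor, and the count of heavy atoms changes by one. The step expected in this assay is therefore small, without a clear direction, and is estimated to stay within the scatter, as a 1.2-fold lower number from compound 3 to compound 4 (0.06 log units; within the scatter). Compound 4 is expected to give about 14 10^-6 cm/s, with a range from 7 10^-6 cm/s to 28 10^-6 cm/s.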

Compound 4, apparent permeability: 5.8 10^-6 cm/s
Compound 4: middle estimate off by 2.4-fold (0.38 log units), on the high side; measured number below the stated range.
By their numbers in this assay, from the lowest: compounds 4, 2, 1 and 3 (each within the scatter of the next, the first and the last beyond it).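

In this assay, putting 3-fluoro-5-methylpyridin-2-yl in place of 5-chloropyridin-2-yl on an oxygen on an aromatic ring gives a 2.8-fold lower number from compound 3 to compound 4 (0.45 log units; beyond the scatter), so the read-out responds to a change at this place, even though the entering and leaving groups have the same ring type and the same counts of hydrogen-bond donors and acceptors and differ by only one heavy atom. Going by these compounds alone, the earlier compounds could not show this, as no two of them formed a pair differing in one place, and this step remains the only such comparison in the set. No measurement is available that explains the size or direction of the step.

The change removes a chlorine and brings in both a fluorine and a methyl, so this single step cannot divide the drop among those three alterations. As far as these compounds go, it remains open how the same place would respond to a pyridin-2-yl group with no further substituent, or to a pyridin-2-yl group carrying a methoxy group or an amine.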